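Expected Tolerance of Compound 3 After One Added Group

The compounds below may be only part of what the source reports. "The series", "measured", "known", "first", "only" and "open" are said of these compounds alone.

Of the compounds shown here, two have so far been measured in an ADME assay on MDCK cells (Canis lupus familiaris) for cytotoxicity; a lower number here means that less compound is tolerated, a higher number that more compound is tolerated. Compound 1 `Cc1ncc(Sc2nccn2C)c(-c2ccccc2O)n1` gives 577000 ug/mL. Going by the values given here, compound 2 `CC(C)(C)c1nccc(-c2ccccc2O)n1` gives 16300 ug/mL, the lower of the two numbers; its only neighbour, compound 1, stands far higher, a gap beyond the scatter. Compound 1 and compound 2 differ in more than one place, so no single step can be read off between them.

Compound 3 `Cn1ccnc1Sc1cnc(C(C)(C)C)nc1-c1ccccc1O` has not yet been measured. It differs from compound 2 by (1-methyl-1H-imidazol-2-yl)sulfanyl in place of hydrogen on an aromatic carbon. Among the compounds with values here, the entering group is the one compound 1 also carries, while the tert-butyl group of compound 2 is kept. Without a one-change step to lean on, the direction is expected to be toward a higher, more tolerated number, as the two values of compound 1 and compound 2 suggest, but the size is uncertain. The step from compound 2 to compound 3 is expected to be a 7.4-fold higher number from compound 2 to compound 3 (0.87 log units; beyond the scatter). Compound 3 is therefore estimated at 120000 ug/mL, within a range from 20000 ug/mL to 600000 ug/mL.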

Compound 3, half-maximal cytotoxic concentration: 194000 ug/mL
Beside the measured number, compound 3's estimate is 1.6-fold (0.21 log units) below it; the range from low to high includes it.
By their numbers in this assay, from the lowest: compound 2; then compound 3; then compound 1.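

In this assay, putting (1-methyl-1H-imidazol-2-yl)sulfanyl on the aromatic carbon para to the tert-butyl group gives a 12-fold higher number from compound 2 to compound 3 (1.08 log units; beyond the scatter) and so shows, through one change alone, that this position responds strongly to the entering group. With that group kept, tert-butyl in place of methyl on an aromatic carbon gives a 3.0-fold lower number from compound 1 to compound 3 (0.47 log units; beyond the scatter) and is a modest step, so the group at the other position also matters, though less than the large step seen here. Nothing available explains why either change moves the number.

Going by these compounds alone, only one group has been seen at this aromatic carbon, so it remains open whether an amine or a simple methylsulfanyl group would shift the number as far. From the compounds shown here alone, it is also open whether the entering group would bring a step of similar size with methyl in place of tert-butyl.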